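This account rests on a few compounds, and the source may have more. Where it says the series, first, only, none or still open, it means among the compounds named here.

Three compounds sharing one core differ only in the group on a sulfonyl sulfur. In a functional assay on HT-29 cells (Homo sapiens) for inhibition, read by CellTiter-Glo, with a stated time of 72 h (on this read-out lower numbers stand for higher toxicity in this test and higher numbers for lower toxicity in this test), compound 1 `CC1=C(CC(=O)N(C)CCN(C)S(C)(=O)=O)c2cc(F)ccc2/C1=C\c1ccc([S+](C)[O-])cc1` with methyl on that sulfur gives 12400 nM as its reading. Compound 2 `CC1=C(CC(=O)N(C)CCN(C)S(=O)(=O)c2ccccc2)c2cc(F)ccc2/C1=C\c1ccc([S+](C)[O-])cc1` with phenyl gives 6090 nM on the same test, and compound 3 `CC1=C(CC(=O)N(C)CCN(C)S(=O)(=O)c2cccc3ccccc23)c2cc(F)ccc2/C1=C\c1ccc([S+](C)[O-])cc1` with naphthalen-1-yl gives 3990 nM there. Compound 3 stands clearly apart from the methyl compound, with a 3.1-fold lower number from compound 1 to compound 3 (0.49 log units; beyond the scatter) as a modest move, yet it cannot be separated from the phenyl compound, since a 1.5-fold lower number from compound 2 to compound 3 (0.18 log units; within the scatter) stays within the normal noise of such measurements.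

Compound 4 `CC1=C(CC(=O)N(C)CCN(C)S(=O)(=O)c2cccc3c(N(C)C)cccc23)c2cc(F)ccc2/C1=C\c1ccc([S+](C)[O-])cc1` carries one further change on compound 3, namely dimethylamino in place of hydrogen on an aromatic carbon as dimethylamino in place of hydrogen on an aromatic carbon. Going by the values given here, no measured step adds this group, so the closest guides are the changes to the same sulfonyl substituent, where a 2.0-fold lower number from compound 1 to compound 2 (0.31 log units; beyond the scatter) was only modest. Compound 3 then shows a 1.5-fold lower number from compound 2 to compound 3 (0.18 log units; within the scatter) as a change inside the scatter, so in this assay no step beyond the scatter is expected from this further addition. The estimated move is a 1.1-fold lower number from compound 3 to compound 4 (0.06 log units; within the scatter) and so remains within that noise. The expected value for compound 4 is 3500 nM with 1500 nM to 8000 nM as its estimated range.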

Compound 4, half-maximal cytotoxic concentration: 10600 nM
Compound 4: the middle estimate sits 3.0-fold (0.48 log units) below what was measured; the whole stated range lies below it.
By their numbers in this assay, from the lowest: compounds 3, 2, 4 and 1 (each within the scatter of the next, the first and the last beyond it).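

In this assay, the naphthalen-1-yl group of compound 3 proves sensitive to substitution on its ring: placing dimethylamino on that aromatic carbon gives a 2.7-fold higher number from compound 3 to compound 4 (0.42 log units; beyond the scatter). This is a small addition, yet its step lies beyond the scatter, whereas the earlier exchange of phenyl for naphthalen-1-yl, a 1.5-fold lower number from compound 2 to compound 3 (0.18 log units; within the scatter), stayed within it, and it runs opposite to the earlier moves away from methyl, so a higher number here means lower toxicity in this test and compound 4 goes against any idea that adding atoms to the sulfonyl substituent steadily lowers the number. Nothing available here accounts for this reversal.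

Still open, as far as these compounds go, is whether the step belongs to dimethylamino itself or would also follow from a plain amino group, a methoxy group or a carboxylic acid on the same carbon. It is also unknown whether dimethylamino would move the number in the same direction on the phenyl group of compound 2, or on a different carbon of the naphthalen-1-yl group.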